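Adding a nitrile to the benzyl group of compound 2

The compounds below may be only part of what the source reports. "The series", "measured", "known", "first", "only" and "open" are said of these compounds alone.

Measured compounds:
compound 1, `COc1ccc(-n2cc(CNC(=O)c3cccc4c3cnn4C(C)C)nn2)cc1`; compound 2, `CC(C)n1ncc2c(C(=O)NCc3cn(Cc4ccccc4)nn3)cccc21`

In a functional assay on HepG2 cells (Homo sapiens) for inhibition, read by MTT assay, with a stated time of 72 h (a lower number here means a stronger inhibitor, a higher number a weaker inhibitor), compound 1 reaches only the assay limit, > 40000 nM. In this assay, among the measured compounds shown here, compound 2 gives 13700 nM, the only real number in this set, and it stands as the sole measured point to reason from. For the measured compounds named here, the step of an at least 2.9-fold lower number from compound 1 to compound 2 (0.46 log units; beyond the scatter) is the one measured change, and it concerns a different part of the molecule.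

Compound 3, `CC(C)n1ncc2c(C(=O)NCc3cn(Cc4ccc(C#N)cc4)nn3)cccc21`, differs from compound 2 by cyano in place of hydrogen on an aromatic carbon. Going by the values given here, no measured step touches this position, so no shift beyond the scatter is expected, and the estimate for compound 3 is set close to compound 2. The expected step of a 1.1-fold lower number from compound 2 to compound 3 (0.06 log units; within the scatter) is therefore small. In this assay compound 3 is estimated at 12000 nM, within a range from 4000 nM to 36000 nM.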

Compound 3, half-maximal inhibitory concentration: > 40000 nM
Compound 3 gave a limit, no number (the forecaster's own chance of this, stated with the estimate: 15%); middle value at least 3.3-fold (0.52 log units) away from the limit.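

In this assay, among the compounds shown here, the change gives an at least 2.9-fold higher number from compound 2 to compound 3 (0.46 log units; beyond the scatter) on a ring where no earlier step had been measured. This shows that the position is not indifferent to what it carries: putting a nitrile on the benzyl group, making it 4-cyanobenzyl, is enough to weaken compound 2 beyond the scatter. Going by these compounds, compound 3 reaches only a limit of the assay, so this step is a minimum whose true size is unknown, and the step between compound 1 and compound 3 cannot be read, because both values are limits: the limit of > 40000 nM in this assay, at which 2 of the 3 values shown sit.

On these data alone, it remains open whether the weakening is particular to the nitrile or follows from any group at this place. A fluorine atom, an amine or a carboxylic acid on the same ring carbon could show which groups compound 2 tolerates there.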